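The source may hold more compounds than are shown below. What is called first, only, known or untested is meant among the compounds shown, and "the series" means these compounds.

Working notes on the series. In a functional assay on HeLa cells (Homo sapiens) for cytotoxicity, read by WST assay, with a stated time of 48 h (a lower number here means a stronger inhibitor, a higher number a weaker inhibitor), compound 1 `COc1cc(C(c2ccc(O)c(OC)c2)[C@H](C)[C@H](C)CO)ccc1O` gives only a limit, > 100000 nM. Compound 2 `COc1cc(C(c2ccc(O)c(OC)c2)[C@@H](C)C(C)C)ccc1O` gives 19000 nM. Compound 3 `CC[C@H](C(C)C)C(c1ccc(O)c(OC)c1)c1ccc(O)c(OC)c1` gives 9700 nM, and these two numbers sit within the scatter of each other, a 2.0-fold lower number from compound 2 to compound 3 (0.29 log units; within the scatter). Both chains without hydroxymethyl separate from compound 1: an at least 5.2-fold lower number from compound 1 to compound 2 (0.72 log units; beyond the scatter) and an at least 10-fold lower number from compound 1 to compound 3 (1.01 log units; beyond the scatter).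

Compound 4 `COc1cc(C(c2ccc(O)c(OC)c2)[C@@H](CF)C(C)C)ccc1O` is not yet measured in this assay. Its change is 1-(fluoromethyl)-2-methylpropyl in place of 1-isopropylpropyl on a saturated chain carbon bound to two aromatic carbons. Going by the values given here, no measured compound carries fluorine, which leaves only indirect guidance. The closest comparison is the small step of a 2.0-fold lower number from compound 2 to compound 3 (0.29 log units; within the scatter) between the two chains without hydroxymethyl. The large step of an at least 10-fold lower number from compound 1 to compound 3 (1.01 log units; beyond the scatter) shows that a substituted chain can cost much, and this argues for a wide range on the upper side. The estimated step is a 1.4-fold higher number from compound 3 to compound 4 (0.16 log units; within the scatter), expected to stay within the scatter. For compound 4 the expected value is 14000 nM, with an estimated range of 6000 nM to 40000 nM.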

Compound 4, half-maximal inhibitory concentration: 41000 nM
Beside the measured number, compound 4's estimate is 2.9-fold (0.47 log units) below it, outside the stated range (above it).
By their numbers in this assay, from the lowest: compounds 3 and 2 (each within the scatter of the next); then compound 4. At a limit, above all of these: compound 1.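

Going by these compounds alone, at the saturated chain carbon bound to two aromatic carbons, the chain of compound 4 is the first to separate from the chains without hydroxymethyl in this assay: a 4.2-fold higher number from compound 3 to compound 4 (0.63 log units; beyond the scatter) and a 2.2-fold higher number from compound 2 to compound 4 (0.33 log units; beyond the scatter). The single fluoro in place of hydrogen thus moves the number beyond the scatter, which the step between compounds 2 and 3 did not do, while the number still stays on the lower side of compound 1, with an at least 2.4-fold lower number from compound 1 to compound 4 (0.38 log units; beyond the scatter). Compound 1 is known only as a limit: the limit of > 100000 nM in this assay, at which 1 of the 4 values shown sits.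

On these data alone, whether the rise belongs to fluorine itself or to any substituent at that end of the chain stays open. A methoxymethyl or aminomethyl chain, or a longer chain, at the same place would separate these readings.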